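This account rests on a few compounds, and the source may have more. Where it says the series, first, only, none or still open, it means among the compounds named here.

Working notes on the series. Compound 1 `COc1ccccc1C(=O)NCc1ccc(CNS(=O)(=O)c2ccccc2C)cc1` gives 1000 nM in an assay on MDA-MB-231 cells for displacement of a labelled ligand from C-X-C chemokine receptor type 4 (Homo sapiens), read by fluorescence and microscopy, with stated times of 10 min and 30 min; on this read-out lower numbers stand for an effect already at smaller amounts and higher numbers for an effect only at larger amounts of compound; compound 2 `Cc1ccccc1S(=O)(=O)NCc1ccc(CNC(=O)c2cccnc2)cc1` gives 1000 nM, and compound 3 `Cc1ccccc1C(=O)NCc1ccc(CNS(=O)(=O)c2ccccc2C)cc1` gives 10 nM. Compound 2 thus stands level with compound 1, the pair together at the highest numbers of the three, the step of no change at the digits printed from compound 1 to compound 2 (within the scatter) lying within the scatter, while the steps of a 100-fold lower number from compound 2 to compound 3 (2.00 log units; beyond the scatter) and a 100-fold lower number from compound 1 to compound 3 (2.00 log units; beyond the scatter) are large. Compound 4 `O=C(NCc1ccc(CNS(=O)(=O)c2ccc([N+](=O)[O-])cc2)cc1)c1cccnc1` differs from compound 2 by 4-nitrophenyl in place of 2-methylphenyl on a sulfonyl sulfur. Among the compounds with values here, none of the measured steps touches the group on the sulfonyl sulfur; all three concern the carbonyl side, so they give no direction for this change. Compound 4 is therefore expected at 1000 nM, range 300 nM to 3000 nM, so the expected step of no change at the digits printed from compound 2 to compound 4 (within the scatter) lies within the scatter.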

Compound 4, effective concentration (reported as EC, without a stated level of effect): 100 nM
Estimate against measurement, compound 4: 10-fold (1.00 log units) above; the measured number lies below the stated range.
By their numbers in this assay, from the lowest: compound 3; then compound 4; then compounds 1 and 2 (each within the scatter of the next).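

The group on the sulfonyl sulfur is now shown to move the read-out, with 4-nitrophenyl in place of 2-methylphenyl (a 10-fold lower number from compound 2 to compound 4 (1.00 log units; beyond the scatter)). The carbonyl side is therefore not the only place that matters, since this step occurs with pyridin-3-yl held constant on the carbonyl carbon. No measurement available here explains the step.

Going by these compounds, whether 4-nitrophenyl acts the same way with the 2-methylphenyl carbonyl group of compound 3 remains open. On these data alone, it is also open whether the nitro group or the loss of methyl carries the step, and whether an amine or a carboxylic acid in place of nitro would hold it.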